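Fluoro in place of methyl on the para-substituted phenyl

A few compounds are considered here, and "the series" means these few. Any claim that something is new, unique, unknown or untested is made for them only; others in the source may bear on it.

Compound 3 `Cc1ccc(-c2cc3c(n2-c2ccc(O)c(C(=O)O)c2)CCCC3)cc1` gives 30% in a functional assay on the whole organism (strain Wistar) for inhibition, with Rattus norvegicus as the target, read by paw edema, with stated times of 30 min and 3 h, at a dose of 200 mg/kg by the oral route (on this read-out lower numbers stand for less inhibition and higher numbers for more inhibition at the one dose given (going by the name of the read-out)), the lowest of the two plain numbers shown; compound 2 `COc1ccc(-c2cc3c(n2-c2ccc(O)c(C(=O)O)c2)CCCC3)cc1` gives 50%. Compound 1 `O=C(O)c1cc(-n2c(-c3ccccc3)cc3c2CCCC3)ccc1O` reaches only a limit of the assay, >= 60% (the limit of >= 60% in this assay, at which 1 of the 3 values shown sits). Compound 4 `O=C(O)c1cc(-n2c(-c3ccc(F)cc3)cc3c2CCCC3)ccc1O` differs from compound 3 by fluoro in place of methyl on an aromatic carbon. Within the data shown here, no measured step swaps methyl for fluoro. From the compounds shown here alone, the steps that touch the same carbon are a number at least 30 percentage points lower from compound 1 to compound 3 (beyond the scatter) and a number 20 percentage points lower from compound 2 to compound 3 (beyond the scatter), both losses when methyl arrives, so removing methyl is expected to recover some inhibition, though what fluoro itself adds is unknown. The expected step is a number 12 percentage points higher from compound 3 to compound 4 (beyond the scatter). Compound 4 is therefore estimated at 42%, between 22% and 60%.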

Compound 4, a percentage reported as inhibition, in the whole organism at one dose (the size of the read-out at that dose, not a potency): >= 60%
Compound 4: no number, only a limit (the forecaster's own chance of this, stated with the estimate: 15%); at least 18 percentage points between middle value and limit.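

In this assay, the swap from 4-methylphenyl to 4-fluorophenyl gives a number at least 30 percentage points higher from compound 3 to compound 4 (beyond the scatter) at this position, so the loss seen with methyl does not extend to fluoro. Fluoro in place of methoxy on the same carbon gives a number at least 10 percentage points higher from compound 2 to compound 4 (that floor lies within the scatter) as the only reading for that pair. Compound 4 gives a limit of the assay and not a number, and its step from compound 1 cannot be read, leaving fluoro and hydrogen here unseparated: the limit of >= 60% in this assay, at which 2 of the 4 values shown sit.

From the compounds shown here alone, how far compound 1 and compound 4 lie past that limit stays open. Also open, going by these compounds, is what chloro, an amine or a carboxylic acid would give on this carbon.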